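The source may hold more compounds than are shown below. What is called first, only, known or untested is meant among the compounds shown, and "the series" means these compounds.

Of the compounds shown here, two of a shared core have been measured in a functional assay on CCRF-CEM cells (Homo sapiens) for inhibition, read by sulforhodamine B assay, with a stated time of 48 h; a lower number here means a stronger inhibitor of growth, a higher number a weaker inhibitor of growth. Compound 1 `COc1ccc(-c2cc(/C=C/C(=O)c3ccc(OC)c(OC)c3)[nH]n2)cc1` gives 4140 nM. Compound 2 `COc1cc(-c2cc(/C=C/C(=O)c3ccc(Cl)c(Cl)c3)[nH]n2)cc(OC)c1OC` gives 23500 nM, the higher of the two numbers, so it is the weaker growth inhibitor of the pair, and the gap to compound 1 lies beyond the usual scatter. Compound 3 `COc1ccc(C(=O)/C=C/c2cc(-c3cc(OC)c(OC)c(OC)c3)n[nH]2)cc1OC` differs from compound 2 by a single change: 3,4-dimethoxyphenyl in place of 3,4-dichlorophenyl on a carbonyl carbon. Because compound 1, which also carries a 3,4-dimethoxyphenyl on the carbonyl carbon, gives 4140 nM, a step downward from compound 2 is expected, of size a 4.7-fold lower number from compound 2 to compound 3 (0.67 log units; beyond the scatter). Compound 3 is estimated at 5000 nM, within 1500 nM to 16000 nM.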

Compound 3, concentration for total growth inhibition: 3930 nM
Beside the measured number, compound 3's estimate is 1.3-fold (0.10 log units) above it, within the range that was stated.
By their numbers in this assay, from the lowest: compounds 3 and 1 (each within the scatter of the next); then compound 2.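

In this assay putting 3,4-dimethoxyphenyl in place of 3,4-dichlorophenyl on a carbonyl carbon gives a 6.0-fold lower number from compound 2 to compound 3 (0.78 log units; beyond the scatter) with the rest of the molecule unchanged. This direct comparison shows that the group at this position matters for growth inhibition, and that 3,4-dimethoxyphenyl is the better of these two groups. No measurement here explains the difference. On these data alone, only these two groups can be compared at this position, so it remains open how an unsubstituted phenyl or a ring carrying an amine would behave.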